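Flipping One Stereocentre in a Fused Bicyclic Amine

The compounds below may be only part of what the source reports. "The series", "measured", "known", "first", "only" and "open" are said of these compounds alone.

compound 1 `c1cc2c(cn1)[C@H]1N3CCC1(CC3)C2`: 962 nM
compound 2 `c1cc2c(cn1)C1N3CCCC1(CC3)C2`: 1040 nM; 318 nM (2 entries)

Among the measured compounds shown here, in an assay for displacement of a labelled ligand from Neuronal acetylcholine receptor; alpha4/beta2 (Rattus norvegicus) (on this read-out lower numbers stand for stronger inhibition and higher numbers for weaker inhibition), compound 1 gives 962 nM, the only number it has. Its close relative compound 2 gives 1040 nM; 318 nM (2 entries), and the spread of the several entries of compound 2 in this assay, 1040 nM; 318 nM (2 entries) shows how far repeat measurements can sit apart. Compound 3 `c1cc2c(cn1)[C@@H]1N3CCC1(CC3)C2` has the same atoms and bonds as compound 1; the difference is the two compounds have the same atoms and bonds; at least one stereo element is drawn with a configuration in one of them and without one in the other: 1 of 3 stereo elements differ; a stereocentre at a saturated ring carbon is drawn S in compound 1 and R in compound 3. For the measured compounds named here, no measured pair here shows what inverting such a stereocentre does, so the direction is open: the shift could go either way or stay within the scatter. Compound 3 is expected to give 1500 nM, between 250 nM and 9000 nM. The expected step of a 1.6-fold higher number from compound 1 to compound 3 (0.19 log units; within the scatter) is therefore uncertain and wide.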

Compound 3, inhibition constant: 1360 nM
Estimate against measurement, compound 3: 1.1-fold (0.04 log units) above, within the range that was stated.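

Inverting a stereocentre at a saturated ring carbon now has a measured result: in this assay the change gives a 1.4-fold higher number from compound 1 to compound 3 (0.15 log units; within the scatter). At this position, then, the two drawn configurations cannot be told apart in this assay. Repeat measurements of a close relative sit further apart than this pair, as shown by this: the several entries of compound 2 in this assay, 1040 nM; 318 nM (2 entries)

As far as these compounds go, how cleanly the pair reports on one configuration against the other stays open, given this: the fact that one of compounds 1 and 3 is drawn with a defined configuration and the other without, at the place where they differ Also open is whether adding a group to the shared core, such as an amine or a carboxylic acid, would make this stereocentre matter.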